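This account rests on a few compounds, and the source may have more. Where it says the series, first, only, none or still open, it means among the compounds named here.

Measured so far in an assay on isolated protein for inhibition of Rho-associated protein kinase 2 (Homo sapiens), read by radiometric assay; on this read-out lower numbers stand for stronger inhibition and higher numbers for weaker inhibition:
compound 1 `CCCCOC(=O)c1cccc(-c2cc(C(=O)Nc3ccncc3)ccc2CN)c1` — compound 1 gives 5.5 nM
compound 2 `NCc1ccc(C(=O)Nc2ccncc2)cc1-c1cccc(C(=O)OCC2CCCCC2)c1` — compound 2 gives 48 nM
compound 3 `NCc1ccc(C(=O)Nc2ccncc2F)cc1-c1cccc(C(=O)OCC2CCCO2)c1` — compound 3 gives 2.5 nM

Compound 3 stands lowest of the three numbers in this assay; compound 1 is nearest to it, compound 2 furthest. Compound 3 and compound 1 differ in two places, so their values are set side by side only as they stand.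

Compound 4 `CCCOC(=O)c1cccc(-c2cc(C(=O)Nc3ccncc3F)ccc2CN)c1` differs from compound 3 by ethyl in place of oxolan-2-yl on a saturated chain carbon bound to an oxygen next to a carbonyl group. Going by the values given here, the one measured step at this place is an 8.7-fold higher number from compound 1 to compound 2 (0.94 log units; beyond the scatter), where a bulkier group on the ester chain carbon went with the higher number. The step to compound 4 runs the other way in size, from a ring to a short open chain, and compound 1 with an open chain already gives a low number in this assay. The expected step in this assay is therefore small, if anything a slightly higher number, and most likely within the scatter: the step from compound 3 to compound 4 is estimated at a 1.6-fold higher number from compound 3 to compound 4 (0.20 log units; within the scatter). Compound 4 is expected to give 4 nM in this assay, with a range from 1.5 nM to 12 nM.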

Compound 4, half-maximal inhibitory concentration: 5.1 nM
For compound 4 the middle estimate is 1.3-fold (0.11 log units) below the measured one; low and high end bracket the measured number.
By their numbers in this assay, from the lowest: compound 3; then compounds 4 and 1 (each within the scatter of the next); then compound 2.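

In this assay the change from oxolan-2-yl to ethyl on the saturated chain carbon bound to an oxygen next to a carbonyl group gives a 2.0-fold higher number from compound 3 to compound 4 (0.31 log units; beyond the scatter) and thus places the ring-bearing ester at the lower number of this pair. Set beside an 8.7-fold higher number from compound 1 to compound 2 (0.94 log units; beyond the scatter) where the ring-bearing ester, with cyclohexyl in place of propyl, had the higher number, this shows that a ring at this place does not by itself fix the direction of the step, although compound 3 and compound 4 carry a fluorine that compound 1 and compound 2 lack. No measurement at hand bears on the origin of either step.

The compounds shown leave open whether the ring oxygen of oxolan-2-yl matters here, which cyclopentyl on the same chain carbon would separate from ring size alone, and how a carboxylic acid or an amide in place of the ester would read. Going by these compounds alone, they also hold no pair differing only in the fluorine, so its own contribution and whether the two steps at the ester carry over between the fluorinated and unfluorinated compounds remain unresolved.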